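A few compounds are considered here, and "the series" means these few. Any claim that something is new, unique, unknown or untested is made for them only; others in the source may bear on it.

Measured in an ADME assay on MT4 cells (Homo sapiens) for cytotoxicity, read by MTT assay, with a stated time of 5 days (on this read-out higher numbers stand for lower toxicity in this test and lower numbers for higher toxicity in this test), so far:
- Compound 1 `CNc1cc(Oc2c(OC)cc3cc(C#N)ccc3c2OC)nc(Nc2ccc(C#N)cc2)n1` gives 239000 nM as a number
- Compound 2 `COc1cc2cc(C#N)ccc2c(OC)c1Oc1cc(NCCC2=CCCCC2)nc(Nc2ccc(C#N)cc2)n1` gives > 125000 nM as a limit

Compound 2 therefore stands at a limit and not at a number. Compound 3 `COc1cc2cc(C#N)ccc2c(OC)c1Oc1cc(NCCCCO)nc(Nc2ccc(C#N)cc2)n1` carries 2-hydroxyethyl in place of cyclohex-1-en-1-yl on a saturated chain carbon, two bonds along the chain from a nitrogen on an aromatic ring. Among the compounds with values here, the only measured step (a step that the limit leaves unreadable from compound 1 to compound 2) offers no size to build on. Within the data shown here, compound 1 at 239000 nM is the one true number, so no step beyond the usual scatter is expected in this assay for this change. The estimated step is a step that the limit leaves unreadable from compound 2 to compound 3 on these figures. For compound 3 the expected value is 150000 nM with an estimated range from 50000 nM to 320000 nM in this test.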

Compound 3, half-maximal cytotoxic concentration: 39100 nM
Compound 3: middle estimate off by 3.8-fold (0.58 log units), on the high side; the measured number lies below the stated range.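

In this assay, putting 2-hydroxyethyl in place of cyclohex-1-en-1-yl gives an at least 3.1-fold lower number from compound 2 to compound 3 (0.50 log units; beyond the scatter) on this chain. Putting 3-hydroxypropyl in place of hydrogen gives a 6.1-fold lower number from compound 1 to compound 3 (0.79 log units; beyond the scatter) as well, so this position does respond to the group it carries. The step from compound 1 to compound 2 cannot be read, because compound 2 stands at a limit: the limit of > 125000 nM in this assay, at which 1 of the 3 values shown sits.

Still open, on these data alone, is whether the hydroxyl or the missing ring matters here. An amine or a carboxylic acid at the end of the same chain would bear on that question.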